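This account rests on a few compounds, and the source may have more. Where it says the series, first, only, none or still open, it means among the compounds named here.

Values for the series in a functional assay on HCT-116 cells (Homo sapiens) for inhibition, read by MTT assay, with a stated time of 48 h (on this read-out higher numbers stand for weaker inhibition and lower numbers for stronger inhibition), are as follows.

Compound 1 `COc1ccc(-c2cc(-c3cc(OC)c(OC)c(OC)c3)nc(-c3ccccc3)n2)c(OC)c1` gives > 25000 nM, which is an assay limit and not a number
Compound 2 `COc1ccc(-c2cc(-c3cc(OC)c(OC)c(OC)c3)nc(-c3ccccc3)n2)cc1` gives 4780 nM
Compound 3 `COc1cc(-c2cc(-c3ccc(O)cc3)nc(-c3ccccc3)n2)cc(OC)c1OC` gives 11900 nM

Of the two values that are true numbers, compound 3 holds the higher one, so it is the weaker of that pair. The gap to its nearest neighbour is a 2.5-fold higher number from compound 2 to compound 3 (0.40 log units; beyond the scatter).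

The next structure is compound 4 `COc1cc(-c2cc(-c3ccc(N)cc3)nc(-c3ccccc3)n2)cc(OC)c1OC`, with the change amino in place of hydroxy on an aromatic carbon, para to a large group.

For the measured compounds named here, no measured step introduces amino, so the evidence is indirect. Going by the values given here, the closest precedent acts on the same oxygen, a 2.5-fold higher number from compound 2 to compound 3 (0.40 log units; beyond the scatter), and it is modest. Two further steps start from a limit and give bounds only, an at least 5.2-fold lower number from compound 1 to compound 2 (0.71 log units; beyond the scatter) and an at least 2.1-fold lower number from compound 1 to compound 3 (0.32 log units; beyond the scatter). Together they show that this substituent position responds to change, but only moderately where true numbers exist.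

The swap keeps the counted donors and acceptors unchanged, so a step beyond the scatter is not expected, with a slight lean towards a lower number. The estimated step is a 1.5-fold lower number from compound 3 to compound 4 (0.17 log units; within the scatter) and remains an expectation only. For compound 4 the expected value is 8000 nM, with an estimated range of 2500 nM to 25000 nM as the likely span.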

Compound 4, half-maximal inhibitory concentration: 12300 nM
Estimate against measurement, compound 4: 1.5-fold (0.19 log units) below; measured number inside the range.
By their numbers in this assay, from the lowest: compound 2; then compounds 3 and 4 (each within the scatter of the next). At a limit, above all of these: compound 1.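

In this assay amino in place of hydroxy gives a 1.0-fold higher number from compound 3 to compound 4 (0.01 log units; within the scatter), so amino and hydroxy cannot be told apart on this read-out. What the earlier compounds could not show is that the rise seen on leaving methoxy is not confined to hydroxy, since a 2.6-fold higher number from compound 2 to compound 4 (0.41 log units; beyond the scatter) sits alongside a 2.5-fold higher number from compound 2 to compound 3 (0.40 log units; beyond the scatter) and no compound among these three goes against it. The remaining step, an at least 2.0-fold lower number from compound 1 to compound 4 (0.30 log units; that floor lies within the scatter), cannot be read, because its starting value is an assay limit and its floor lies within the scatter: the limit of > 25000 nM in this assay, at which 1 of the 4 values shown sits.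

Only methoxy, hydroxy and amino are shown on this aromatic carbon, so it remains open whether methoxy is itself favoured or whether a longer ethoxy, a dimethylamino or a chlorine there would match compound 2. On these data alone, whether the tie between compound 3 and compound 4 would hold with other groups elsewhere on the shared core also remains open.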